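The source may hold more compounds than are shown below. What is called first, only, known or untested is meant among the compounds shown, and "the series" means these compounds.

Compound 1, `C#CCCOc1ccc2cc(C(=O)OC)c(=O)oc2c1`, and compound 2, `C#CCCCOc1ccc2cc(C(=O)OC)c(=O)oc2c1`, share one core and differ in one place: propargyl in place of ethynyl on a saturated chain carbon, two bonds along the chain from an oxygen on an aromatic ring. In an assay on cells for inhibition of Amine oxidase [flavin-containing] B (Homo sapiens), read by Amplex Red, with stated times of 30 min and 45 min (a higher number here means a weaker inhibitor, a lower number a stronger inhibitor), compound 1 gives 258 nM, and compound 2 gives 82.4 nM, so the step is a 3.1-fold lower number from compound 1 to compound 2 (0.50 log units; beyond the scatter).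

Compound 3, `C#CCCCOc1ccc2oc(=O)c(C(=O)OC)cc2c1`, is built on a different core; how the two cores differ is not broken down here. In this assay compound 3 gives 1440 nM, the highest of the three numbers, a weaker inhibitor than either compound 1 or compound 2 by steps that lie beyond the usual scatter.

Compound 4, `C#CCCCCOc1ccc2oc(=O)c(C(=O)OC)cc2c1`, carries the change (propargyl in place of ethynyl on a saturated chain carbon, three bonds along the chain from an oxygen on an aromatic ring). Within the data shown here, this is the same kind of change as the one from compound 1 to compound 2, with one difference around the place: there it sits two bonds along the chain from the oxygen on the aromatic ring, here three bonds along. Because the earlier step was a 3.1-fold lower number from compound 1 to compound 2 (0.50 log units; beyond the scatter), a step of similar direction but somewhat smaller size is expected here, about a 2.6-fold lower number from compound 3 to compound 4 (0.42 log units; beyond the scatter), since the core and the place are not the same. Compound 4 is therefore estimated at 550 nM, within a range from 250 nM to 1500 nM.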

Compound 4, half-maximal inhibitory concentration: 123 nM
Compound 4: the middle estimate sits 4.5-fold (0.65 log units) above what was measured, and the stated range ends above it.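

In this assay, the change gives a 12-fold lower number from compound 3 to compound 4 (1.07 log units; beyond the scatter), so adding to the chain lowers the number on the core of compound 3 as it does on the core of compound 1. Among these compounds, the direction of the step therefore carries from one core to the other, but its size does not, and the two steps differ by more than the usual scatter: the same change on two cores in this assay, a 3.1-fold lower number (0.50 log units; beyond the scatter) from compound 1 to compound 2 and a 12-fold lower number (1.07 log units; beyond the scatter) from compound 3 to compound 4, 3.7-fold (0.57 log units) apart, beyond the scatter of two such steps With only one pair on each core, this does not show why the size differs, nor whether it depends on the core itself or on the chain lengths involved, since the two pairs start from different chains.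

The compounds shown leave open how hex-5-yn-1-yl would behave on the core of compound 1 and but-3-yn-1-yl on the core of compound 3, which would set the same chains side by side on both cores. They also leave open whether a longer chain than hex-5-yn-1-yl, or a chain ending in an amine instead of a triple bond, would continue the trend.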